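The source may report more compounds than this note shows. Statements on the series, on what has been measured and on what is new or still open speak of the compounds shown alone.

Measured so far:
- compound 1, `Cc1ccc(-c2nc3c(=O)[nH]c(C)nc3s2)cc1`: 17%
- compound 2, `Cc1nc2sc(-c3ccc(C(F)(F)F)cc3)nc2c(=O)[nH]1`: 1%

Both were tested in an assay on CHO cells for displacement of a labelled ligand from adenosine receptor A1 (Homo sapiens), read by scintillation counting, with a stated time of 120 min, tested at 1 uM; a lower number here means less inhibition, a higher number more inhibition at the concentration tested (going by the name of the read-out). Compound 2 stands lowest of the two numbers, and its nearest neighbour is compound 1, a number 16 percentage points lower from compound 1 to compound 2 (beyond the scatter). Going by the values given here, that step, a trifluoromethyl in place of a methyl on an aromatic carbon, is the only measured change and is modest in size.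

Compound 3, `Cc1nc2sc(-c3ccc(C(=O)O)cc3)nc2c(=O)[nH]1`, is not yet measured. It differs from compound 2 in one place: carboxy in place of trifluoromethyl on an aromatic carbon. Among the compounds with values here, no measured pair shows a carboxy entering or a trifluoromethyl leaving, so the one step on record bears on it only loosely: it shows that a change of the group at this position can move the read-out in this assay by a modest amount. Given that compound 2 already sits at the bottom of the series with 1%, a large drop is not possible, and a large rise has no support in the data.

Compound 3 is therefore expected to give 8%, within 0% to 25%, which means an expected step of a number 7 percentage points higher from compound 2 to compound 3 (within the scatter).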

Compound 3, a percentage reported as inhibition, at one concentration (the size of the read-out at that concentration, not a potency): 1%
The estimate for compound 3 lay 7 percentage points above the measured number; the measured number falls inside the stated range.
By their numbers in this assay, from the lowest: compounds 2 and 3 (each within the scatter of the next); then compound 1.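

Working notes on the group para to a large group, in this assay: carboxy in place of trifluoromethyl on the aromatic carbon gives no change at the digits printed from compound 2 to compound 3 (within the scatter), so two groups that differ in heavy atoms, hydrogen-bond donors and hydrogen-bond acceptors cannot be told apart in this read-out. Methyl now has two replacements to set against it, with a number 16 percentage points lower from compound 1 to compound 2 (beyond the scatter) joined by a number 16 percentage points lower from compound 1 to compound 3 (beyond the scatter), and among the three compounds only compound 1, the methyl compound, stands apart from the others. No data at hand explain why these two replacements read alike or why methyl differs from both.

Open, as far as these compounds go, is whether the higher reading depends on methyl itself or would also be found with a longer chain such as ethyl, or with an amine or a methoxy group at the same place. From the compounds shown here alone, compound 1 gives only 17%, and a reading at one concentration is not a potency, so how far any group at this place could raise inhibition also remains open.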